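The source may hold more compounds than are shown below. What is called first, only, known or untested is meant among the compounds shown, and "the series" means these compounds.

Compound 1 `Cc1cc(-c2cnn3c(NCC4CCOCC4)nc(Oc4cccc(F)c4F)nc23)ccc1C(=O)NC1CC1` gives > 1 h in an ADME assay on microsomes (Homo sapiens) for metabolic stability (a higher number here means that the compound lasts longer, a lower number that the compound disappears faster), which is a limit of the assay and not a number.
Compound 2 `Cc1cc(-c2cnn3c(NCC4CCOCC4)nc(Nc4cccc(F)c4)nc23)ccc1C(=O)NC1CC1` gives > 1 h in this assay, again a limit and not a number.

Compound 2 therefore stands at the edge of what the assay reports, together with every other value shown (the limit of > 1 h in this assay, at which 2 of the 2 values shown sit). Within the data shown here, the one measured step, a step that the two limits leave unreadable from compound 1 to compound 2, runs between two limits, and its size cannot be read. Compound 3 `Cc1cc(-c2cnn3c(NCC4CCOCC4)nc(Nc4ccccc4F)nc23)ccc1C(=O)NC1CC1` differs from compound 2 by 2-fluorophenyl in place of 3-fluorophenyl on a nitrogen on an aromatic ring. This change has no measured counterpart among the compounds above, and the single step shown gives no size, so the expectation rests on compound 2 alone, whose result of > 1 h is a limit. The step from compound 2 to compound 3 in this assay is expected to be a step that the limit leaves unreadable from compound 2 to compound 3, nothing beyond the usual scatter. Compound 3 is estimated at 1.5 h in this assay, within a range of 0.7 h to 4 h, and most likely the assay will again report only a limit.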

Compound 3, half-life: > 1 h
Compound 3: no number, only a limit (the forecaster's own chance of this, stated with the estimate: 75%); the middle value is on the limit's open side.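

Compound 1, compound 2 and compound 3 all end at a limit and not a number, so no step among them can be read: the limit of > 1 h in this assay, at which 3 of the 3 values shown sit.

Still open, as far as these compounds go, is how long each of the three actually lasts in this assay, and so whether 2-fluorophenyl and 3-fluorophenyl differ there at all.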